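Aryl swap on the benzylamine arm of the shared core

This account rests on a few compounds, and the source may have more. Where it says the series, first, only, none or still open, it means among the compounds named here.

compound 1 `Nc1cc(N)c2nc(-c3ccccc3)c(Oc3ccc(Cl)c(Cl)c3)nc2c1`: 33900 nM in a functional assay on Hs-578T cells (Homo sapiens) for inhibition, read by sulforhodamine B assay, with a stated time of 48 h; on this read-out higher numbers stand for weaker inhibition of growth and lower numbers for stronger inhibition of growth
compound 2 `CCOC(=O)[C@H](CCC(=O)O)NC(=O)c1ccc(CNc2nc3cc(N)cc(N)c3nc2-c2ccccc2)cc1`: < 100000 nM, a limit of this assay
compound 3 `Nc1cc(N)c2nc(-c3ccccc3)c(NCc3ccc(Cl)c(Cl)c3)nc2c1`: 46800 nM

Compound 3 holds the higher of the two numbers measured in this assay; compound 1 sits a little lower, but the gap between them is within the scatter, so no order between the two can be claimed. For compound 2 this assay reports only a limit (the limit of < 100000 nM in this assay, at which 1 of the 3 values shown sits), not a number.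

Compound 4 `COc1ccc(CNc2nc3cc(N)cc(N)c3nc2-c2ccccc2)cc1OC` differs from compound 3 in one place: 3,4-dimethoxyphenyl in place of 3,4-dichlorophenyl on a saturated chain carbon bound to a nitrogen on an aromatic ring. Among the compounds with values here, no pair of measured compounds spans a change of this kind, so there is nothing to scale the step against. The expectation is no shift beyond the scatter, with the step from compound 3 to compound 4 estimated as a 1.1-fold higher number from compound 3 to compound 4 (0.03 log units; within the scatter). Compound 4 is expected to give about 50000 nM, between 20000 nM and 120000 nM.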

Compound 4, concentration for total growth inhibition: < 100000 nM
Compound 4 ended at the assay's limit (the forecaster's own chance of this, stated with the estimate: 30%); the middle value is on the limit's open side.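

Within the data shown here, compound 4 gives < 100000 nM as a limit of the assay, and no step from compound 3 to compound 4 can be read. On these data alone, whether 3,4-dimethoxyphenyl in place of 3,4-dichlorophenyl shifts growth inhibition at all stays open.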